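A few compounds are considered here, and "the series" means these few. Any claim that something is new, unique, unknown or untested is made for them only; others in the source may bear on it.

Three compounds of the series have numbers in an assay on HEK293 cells for agonist activity at transient receptor potential cation channel subfamily M member 8 (Homo sapiens), read by fluorescence and calcium flux, with a stated time of 15 min; a higher number here means that more compound is needed for the effect, a lower number that less compound is needed. Compound 1 `CCN(Cc1ccc(C)s1)C(=O)COc1ccc(C)cc1` gives 178 nM. Compound 3 `CCN(Cc1cccn1C)C(=O)COc1ccc(C)cc1` gives 21300 nM. Compound 2 `Cc1ccc(OCC(=O)N(Cc2cccs2)C2COC2)cc1` gives 23000 nM, the highest of the three, within the scatter of compound 3 and far beyond it from compound 1. For the measured compounds named here, the single measured step, a 120-fold higher number from compound 1 to compound 3 (2.08 log units; beyond the scatter), concerns the group on the saturated chain carbon, not the amide nitrogen. Compound 4 `Cc1ccc(OCC(=O)N(Cc2cccs2)c2ccnn2C)cc1` differs from compound 2 at that nitrogen: 1-methyl-1H-pyrazol-5-yl in place of oxetan-3-yl on an amide-type nitrogen. Going by the values given here, no measured step bears on a change at this place; compound 1 carries a small group on this nitrogen with a far lower number, but its other group differs too, so nothing is settled. Compound 4 is expected to give 10000 nM (range 2000 nM to 50000 nM), the estimated step being a 2.3-fold lower number from compound 2 to compound 4 (0.36 log units; beyond the scatter), a lowering that may not exceed the scatter.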

Compound 4, half-maximal effective concentration: 422 nM
Beside the measured number, compound 4's estimate is 24-fold (1.37 log units) above it; the whole stated range lies above it.
By their numbers in this assay, from the lowest: compound 1; then compound 4; then compounds 3 and 2 (each within the scatter of the next).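

On the amide-type nitrogen, the group alone can move the number in this assay by a large amount: 1-methyl-1H-pyrazol-5-yl in place of oxetan-3-yl gives a 55-fold lower number from compound 2 to compound 4 (1.74 log units; beyond the scatter). For the compounds shown here, this is the first measured step at this place, and it sets the group on this nitrogen beside the group on the saturated chain carbon as a place where the number changes beyond the scatter. Nothing measured here accounts for the step.

Which feature of the 1-methyl-1H-pyrazol-5-yl group carries the lowering stays open. So does how a phenyl or a cyclopropyl on this nitrogen would compare.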